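Indazolyl replacement for dimethylphenyl on the shared core

The compounds below may be only part of what the source reports. "The series", "measured", "known", "first", "only" and "open" are said of these compounds alone.

Values in a functional assay on A549 cells (Homo sapiens) for inhibition, read by CCK-8 assay, with a stated time of 48 h; on this read-out lower numbers stand for stronger inhibition and higher numbers for weaker inhibition:
- compound 1 `COc1cc(-c2ccnc3cc(-c4ccc(C)c(C)c4)nn23)cc(OC)c1OC`: 272 nM
- compound 2 `C=Cc1ccc(-c2cc3nccc(-c4cc(OC)c(OC)c(OC)c4)n3n2)cc1`: 1030 nM
- compound 3 `COc1ccc(-c2cc3nccc(-c4cc(OC)c(OC)c(OC)c4)n3n2)cc1`: 376 nM

In this assay compound 1 gives the lowest of the three numbers. Its gap to compound 3 is within the scatter, so the two cannot be ordered; its gap to compound 2 is beyond the scatter. The steps are a 3.8-fold higher number from compound 1 to compound 2 (0.58 log units; beyond the scatter) and a 1.4-fold higher number from compound 1 to compound 3 (0.14 log units; within the scatter), and between the other two a 2.7-fold lower number from compound 2 to compound 3 (0.44 log units; beyond the scatter).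

Compound 4 `COc1cc(-c2ccnc3cc(-c4ccc5cnn(C)c5c4)nn23)cc(OC)c1OC` is not yet measured. It differs from compound 1 by 1-methyl-1H-indazol-6-yl in place of 3,4-dimethylphenyl on an aromatic carbon. For the measured compounds named here, no measured step introduces this group. Going by the values given here, the steps that bear on the change are the two exchanges at the same 3,4-dimethylphenyl, a 3.8-fold higher number from compound 1 to compound 2 (0.58 log units; beyond the scatter) and a 1.4-fold higher number from compound 1 to compound 3 (0.14 log units; within the scatter): one exchange stays within the scatter, the other gives a modest higher number, and none goes to a lower number than compound 1. The expectation for compound 4 is therefore a number near compound 1 or somewhat higher, with wide uncertainty. On that basis a 1.5-fold higher number from compound 1 to compound 4 (0.17 log units; within the scatter) is expected. Compound 4 is estimated at 400 nM, with a range from 150 nM to 1100 nM.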

Compound 4, half-maximal inhibitory concentration: 233 nM
Compound 4: the middle estimate sits 1.7-fold (0.23 log units) above what was measured; the measured number falls inside the stated range.
By their numbers in this assay, from the lowest: compounds 4, 1 and 3 (each within the scatter of the next); then compound 2.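

In this assay, this position on the shared core accepts 1-methyl-1H-indazol-6-yl, with its five-membered aromatic ring with 2 hetero atoms and 2 hydrogen-bond acceptors, in place of a single six-membered aromatic ring without a step that can be told from the scatter: a 1.2-fold lower number from compound 1 to compound 4 (0.07 log units; within the scatter) and a 1.6-fold lower number from compound 3 to compound 4 (0.21 log units; within the scatter). Among the four compounds only the 4-vinylphenyl group stands apart, with a 4.4-fold lower number from compound 2 to compound 4 (0.65 log units; beyond the scatter), so the entering 10 heavy atoms carry no visible penalty here. No measurement at hand accounts for these numbers.

Open, on these data alone, is how the number moves when a hydrogen replaces the methyl on the indazole, or when an amine or a carboxylic acid is carried at this position. As far as these compounds go, the rest of the shared core stays unchanged across all four compounds, so its part in the numbers remains open.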